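Swapping the aryl group on the ring nitrogen

This account rests on a few compounds, and the source may have more. Where it says the series, first, only, none or still open, it means among the compounds named here.

In an assay on CHO cells for displacement of a labelled ligand from adenosine receptor A3 (Homo sapiens), read by scintillation counting, with a stated time of 120 min, tested at 10 uM (a lower number here means less inhibition, a higher number more inhibition at the concentration tested (going by the name of the read-out)), compound 3 `Nc1scc(CN2CCN(c3c(F)cccc3F)CC2)c1C(=O)c1ccc(Cl)cc1` gives 4%, the highest of the three numbers shown, though this lies within the scatter of compound 1 `Nc1scc(CN2CCN(c3ccc(Cl)c(C(F)(F)F)c3)CC2)c1C(=O)c1ccc(Cl)cc1` with 3% and of compound 2 `Nc1scc(CN2CCN(C3CCCCCC3)CC2)c1C(=O)c1ccc(Cl)cc1` with 0%. Compound 4 `Nc1scc(CN2CCN(c3ccc(Cl)c(Cl)c3)CC2)c1C(=O)c1ccc(Cl)cc1` differs from compound 3 in one place: 3,4-dichlorophenyl in place of 2,6-difluorophenyl on an amine nitrogen in a ring. Going by the values given here, the steps that bear on this change all alter the same group on the ring nitrogen: a number 3 percentage points lower from compound 1 to compound 2 (within the scatter), a number 1 percentage points higher from compound 1 to compound 3 (within the scatter) and a number 4 percentage points higher from compound 2 to compound 3 (within the scatter), each within the scatter. Exchanging one aryl group for another, or for cycloheptyl, has therefore left this assay flat across the three measured compounds. Compound 4 is expected to follow the same course, with an estimated step of a number 1 percentage points lower from compound 3 to compound 4 (within the scatter) that stays within the scatter. The estimate for compound 4 is 3%, ranging from -5% to 12%.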

Compound 4, a percentage reported as inhibition, at one concentration (the size of the read-out at that concentration, not a potency): 3%
For compound 4 middle estimate and measured number coincide at the digits printed; low and high end bracket the measured number.
By their numbers in this assay, from the lowest: compounds 2, 1, 4 and 3 (each within the scatter of the next).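

In this assay, 3,4-dichlorophenyl on the ring nitrogen adds a further group to the flat set, with a number 1 percentage points lower from compound 3 to compound 4 (within the scatter) and a number 3 percentage points higher from compound 2 to compound 4 (within the scatter) as its steps. The comparison with compound 1 isolates one substituent on the aromatic ring, chloro in place of trifluoromethyl, and gives no change at the digits printed from compound 1 to compound 4 (within the scatter) in a single exchange. No evidence here explains this flat pattern. The compounds shown leave open whether an amine or a carboxylic acid on the aryl group would move the number. They also leave open whether a longer chain on the ring nitrogen would do so.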